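A few compounds are considered here, and "the series" means these few. Any claim that something is new, unique, unknown or untested is made for them only; others in the source may bear on it.

Compound 1 `O=c1oc2ccccc2cc1C1=NN(c2ccccc2)[C@@H](/C=C/c2ccccc2)C1` gives 26.7% in a functional assay on the whole organism (strain albino) for inhibition, with Rattus norvegicus as the target, read by paw edema, with stated times of 1 h and 2 h, at a dose of 200 mg/kg by the oral route; on this read-out lower numbers stand for less inhibition and higher numbers for more inhibition at the one dose given (going by the name of the read-out). Compound 2 `O=c1oc2ccccc2cc1C1=NN(c2ccccc2)[C@@H](c2ccc(Cl)cc2)C1` gives 39.2% in this assay.

Of the two numbers, compound 2 stands highest; its nearest neighbour is compound 1, and the step of a number 12.5 percentage points higher from compound 1 to compound 2 (beyond the scatter) lies beyond the scatter. Compound 3 `O=c1oc2ccccc2cc1C1=NN(c2ccccc2)[C@@H](c2cccc([N+](=O)[O-])c2)C1` has not yet been measured. It differs from compound 2 in one place: 3-nitrophenyl in place of 4-chlorophenyl on a saturated ring carbon.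

For the measured compounds named here, only one measured step exists, and it concerns the same saturated ring carbon, where a 4-chlorophenyl replaced a 2-phenylethenyl and the inhibition rose by a modest amount. Going by the values given here, no measured pair shows the exchange of a 4-chlorophenyl for a 3-nitrophenyl, so nothing directly tells what this change does. Since both groups are six-membered aromatic rings of carbon only, the writer expects the number for compound 3 to sit close to that of compound 2, with a step of a number 1.2 percentage points lower from compound 2 to compound 3 (within the scatter) that is not expected to go beyond the scatter. For compound 3 the estimate in this assay is 38%, with a range from 24% to 52%.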

Compound 3, a percentage reported as inhibition, in the whole organism at one dose (the size of the read-out at that dose, not a potency): 26.1%
Beside the measured number, compound 3's estimate is 11.9 percentage points above it; the measured number falls inside the stated range.
By their numbers in this assay, from the lowest: compounds 3 and 1 (each within the scatter of the next); then compound 2.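

At this saturated ring carbon, 3-nitrophenyl in place of 4-chlorophenyl gave a number 13.1 percentage points lower from compound 2 to compound 3 (beyond the scatter) in this assay, so two groups that each hold one six-membered aromatic ring of carbon only are not interchangeable at this position. Set against the 2-phenylethenyl group, the 3-nitrophenyl group gave a number 0.6 percentage points lower from compound 1 to compound 3 (within the scatter), which leaves these two groups indistinguishable on this read-out and makes the 4-chlorophenyl group the only one of the three whose steps to both others lie beyond the scatter. No information is at hand that would explain the difference between the 4-chlorophenyl and 3-nitrophenyl groups.

The compounds shown leave open whether the lower number goes with the nitro group or with its place on the phenyl ring, as the two groups differ in both respects, and a 3-chlorophenyl or a 4-nitrophenyl group on the same carbon would separate the two. Also open, going by these compounds, is how this read-out would respond to an amine or a carboxylic acid on that phenyl ring, or to a longer chain at this carbon.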